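Methyl for fluoro on the benzoyl ring: compound 4 expected

The source may report more compounds than this note shows. Statements on the series, on what has been measured and on what is new or still open speak of the compounds shown alone.

Measured so far:
compound 1 `COc1ccc(-c2csc(NC(=O)COc3ccc(C(=O)c4ccc(C)cc4)cc3C)n2)cc1` — 20700 nM
compound 2 `COc1ccc(-c2csc(NC(=O)COc3ccc(C(=O)c4ccc(F)cc4)cc3C)n2)cc1` — 5400 nM
compound 3 `Cc1cc(C(=O)c2ccccc2F)ccc1OCC(=O)Nc1nc(-c2ccccc2)cs1` — 16700 nM

In a functional assay on Ehrlich cells (Mus musculus) for cytotoxicity, read by MTT assay, with a stated time of 48 h (on this read-out higher numbers stand for weaker inhibition and lower numbers for stronger inhibition), compound 2 gives 5400 nM, and the change methyl in place of fluoro on an aromatic carbon yields a 3.8-fold higher number from compound 2 to compound 1 (0.58 log units; beyond the scatter). Compound 3 gives 16700 nM in this assay; the difference between its core and the core of compound 2 is not broken down here. Compound 4 `Cc1cc(C(=O)c2ccccc2C)ccc1OCC(=O)Nc1nc(-c2ccccc2)cs1` is not yet measured. It differs from compound 3 by methyl in place of fluoro on an aromatic carbon, the same kind of change as from compound 2 to compound 1, but at a place that is ortho to a large group rather than para to a large group. Resting on the step from compound 2 to compound 1 a 3.8-fold higher number from compound 2 to compound 1 (0.58 log units; beyond the scatter), compound 4 is expected to give a higher number, with an estimated step of a 2.1-fold higher number from compound 3 to compound 4 (0.32 log units; beyond the scatter) in this assay. For compound 4 the estimate is 35000 nM, between 14000 nM and 90000 nM.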

Compound 4, half-maximal inhibitory concentration: 25800 nM
Compound 4: the middle estimate sits 1.4-fold (0.13 log units) above what was measured, within the range that was stated.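

In this assay, methyl in place of fluoro gives a 1.5-fold higher number from compound 3 to compound 4 (0.19 log units; within the scatter), so on this core the change cannot be told apart from the scatter of repeated measurements. Set beside the earlier step, the two results do not differ measurably: the same change on two cores in this assay, a 3.8-fold higher number (0.58 log units; beyond the scatter) from compound 2 to compound 1 and a 1.5-fold higher number (0.19 log units; within the scatter) from compound 3 to compound 4, 2.5-fold (0.39 log units) apart, within the scatter of two such steps. Going by these compounds alone, this fits a single shared step across both cores but does not establish one, as it rests on only two pairs, and these differ in their core and in the place of the change.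

The compounds shown leave open what an amine or a carboxylic acid would give at this place on the ring. They also leave open how the fluoro-to-methyl step would behave on any further core.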